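A few compounds are considered here, and "the series" means these few. Any claim that something is new, unique, unknown or untested is made for them only; others in the source may bear on it.

Measured so far in an ADME assay on microsomes from liver (Homo sapiens) for metabolic stability, read by LC-MS, using NADPH, tested at 5 uM; on this read-out higher numbers stand for a longer-lived compound and lower numbers for a shorter-lived compound: compound 1 `Cc1cc(S(=O)(=O)/N=C(\N)n2nccc2-c2ccccc2)c(SCc2ccccc2Cl)cc1Cl` gives 0.226 h; compound 2 `Cc1cc(-c2ccccc2)n(/C(N)=N/S(=O)(=O)c2cc(C)c(Cl)cc2SCc2ccccc2C)n1` gives 0.154 h.

Compound 1 carries the higher of the two numbers, but compound 2 sits within the scatter of it, so the pair shows no real separation. Compound 3 `Cc1cc(S(=O)(=O)/N=C(\N)n2nccc2-c2ccccc2)c(SCc2ccccc2)cc1Cl` differs from compound 1 by hydrogen in place of chloro on an aromatic carbon; seen one bond further out, this is 2-chlorobenzyl to benzyl. For the measured compounds named here, no measured pair in the set isolates such a change. The step from compound 1 to compound 3 is expected to be small, at most a modest move downward, and likely inside the scatter: a 1.2-fold lower number from compound 1 to compound 3 (0.08 log units; within the scatter). Compound 3 is accordingly estimated at 0.19 h, with a range of 0.09 h to 0.4 h.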

Compound 3, half-life: 0.0772 h
For compound 3 the middle estimate is 2.5-fold (0.39 log units) above the measured one, outside the stated range (below it).
By their numbers in this assay, from the lowest: compounds 3, 2 and 1 (each within the scatter of the next, the first and the last beyond it).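

In this assay, for the compounds shown here, the change from 2-chlorobenzyl to benzyl gives a 2.9-fold lower number from compound 1 to compound 3 (0.47 log units; beyond the scatter), the first single-place step. This shows that the substituent on this aromatic carbon, ortho to a large group, matters for half-life, with chloro giving the longer-lived compound of this pair. Nothing measured here accounts for the step.

As far as these compounds go, it remains open whether fluoro or methoxy on this carbon would match chloro or hydrogen. From the compounds shown here alone, it is also open whether the same step would appear with other groups elsewhere on the shared core.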